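Replacing the iodo group of compound 3

The compounds below may be only part of what the source reports. "The series", "measured", "known", "first", "only" and "open" are said of these compounds alone.

In a functional assay on MDA-MB-231 cells (Homo sapiens) for antiproliferative activity, read by MTT assay, with a stated time of 72 h (on this read-out higher numbers stand for weaker inhibition and lower numbers for stronger inhibition), compound 1 `O=C(CCc1cccc2c1B(O)OC2)NC1CCCCC1`, which carries cyclohexyl on the amide nitrogen, gives > 100000 nM, and this is a limit of the assay, not a number. Compound 2 `O=C(CCc1cccc2c1B(O)OC2)Nc1ccc(Cl)cc1`, with 4-chlorophenyl there, reads 3600 nM. Compound 3 `O=C(CCc1cccc2c1B(O)OC2)Nc1ccc(I)cc1`, with 4-iodophenyl, reads 33000 nM, the higher of the two actual numbers. Both replacements of cyclohexyl lowered the number, with an at least 27-fold lower number from compound 1 to compound 2 (1.44 log units; beyond the scatter) and an at least 3.0-fold lower number from compound 1 to compound 3 (0.48 log units; beyond the scatter). Compound 4 `CC(C)(C)OC(=O)Nc1ccc(NC(=O)CCc2cccc3c2B(O)OC3)cc1` has (tert-butoxycarbonyl)amino in place of iodo on an aromatic carbon, para to a large group: (tert-butoxycarbonyl)amino in place of iodo on an aromatic carbon. Going by the values given here, the only measured change at that place is the exchange of chloro for iodo, with a 9.2-fold higher number from compound 2 to compound 3 (0.96 log units; beyond the scatter). A modest step towards a lower number is therefore expected in this assay, with compound 2 at 3600 nM as the guide. The expected change is a 2.4-fold lower number from compound 3 to compound 4 (0.37 log units; beyond the scatter). For compound 4 the estimated value is 14000 nM, with an expected range from 3000 nM to 60000 nM.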

Compound 4, half-maximal inhibitory concentration: 29000 nM
Compound 4: the middle estimate sits 2.1-fold (0.32 log units) below what was measured, and the stated range covers the measured number.
By their numbers in this assay, from the lowest: compound 2; then compounds 4 and 3 (each within the scatter of the next). At a limit, above all of these: compound 1.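

In this assay, this position on the aromatic ring accepts (tert-butoxycarbonyl)amino, with 8 heavy atoms and a hydrogen-bond donor, in place of the single iodine of iodo, giving a 1.1-fold lower number from compound 3 to compound 4 (0.06 log units; within the scatter) and no change beyond the scatter. Chloro stays apart, since (tert-butoxycarbonyl)amino in its place gives an 8.1-fold higher number from compound 2 to compound 4 (0.91 log units; beyond the scatter) and so leaves compound 4 on the same side of compound 2 as compound 3. A large rise in the heavy-atom count at this place therefore need not move the number, and among the three compounds only the chloro compound stands apart.

As far as these compounds go, whether a free amine, fluoro or methyl at this place would read with compound 2 or with compounds 3 and 4 stays open. Nothing measured here gives a reason for these steps.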